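A Methyl Added Onto a Methoxy Group: What Solubility May Follow

The compounds below may be only part of what the source reports. "The series", "measured", "known", "first", "only" and "open" are said of these compounds alone.

Measured so far:
compound 1, `CCCN(CCC)CCNc1n[n+]([O-])c2ccc(C(C)C)cc2[n+]1[O-]`, 39000000 nM
compound 2, `CCCN(CCC)CCNc1n[n+]([O-])c2ccc(C(C)(C)C)cc2[n+]1[O-]`, 32000000 nM
compound 3, `COc1ccc2c(c1)[n+]([O-])c(NCCN(C)C)n[n+]2[O-]`, 46000000 nM

All three compounds were examined in a physicochemical assay for solubility, in the presence of a further agent that is not named here; on this read-out higher numbers stand for higher solubility and lower numbers for lower solubility. Compound 1 and compound 2 share one core, and compound 3 is built on a different one; the difference between the two cores is not broken down here. In this assay the three values lie close together, and none of the gaps between them is large enough to count as a real difference.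

One small change has already been tested. From compound 1 to compound 2 the change is methyl in place of hydrogen on a saturated chain carbon bound to an aromatic carbon and two saturated chain carbons, and the step it made was a 1.2-fold lower number from compound 1 to compound 2 (0.09 log units; within the scatter).

The compound still to be measured is compound 4, `CCOc1ccc2c(c1)[n+]([O-])c(NCCN(C)C)n[n+]2[O-]`. It differs from compound 3 by methyl in place of hydrogen on a saturated chain carbon bound to an oxygen on an aromatic ring. Among the measured compounds shown here, this is the same kind of change as the one from compound 1 to compound 2: in both a methyl replaces a hydrogen on a saturated chain carbon. The surroundings differ, though: in the earlier pair that carbon is bound to an aromatic carbon and two saturated chain carbons, while here it is bound to an oxygen on an aromatic ring.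

Since the earlier step stayed within the scatter, the step from compound 3 to compound 4 is expected to be about as small, namely a 1.2-fold lower number from compound 3 to compound 4 (0.08 log units; within the scatter), and compound 4 is estimated to give 38000000 nM in this assay, most likely between 20000000 nM and 70000000 nM.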

Compound 4, solubility: > 50000000 nM
Compound 4 was reported as a limit; the forecaster's own chance of this, stated with the estimate: 5%; middle value at least 1.3-fold (0.11 log units) from the limit.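

In this assay compound 4 is reported as a limit of the assay and not as a number: the limit of > 50000000 nM in this assay, at which 1 of the 4 values shown sits. The step can be read only as a floor, an at least 1.0-fold higher number from compound 3 to compound 4 (0.03 log units; that floor lies within the scatter), and a floor of this size does not establish a real difference in either direction, nor does it give the full size of the step. The same kind of change on the core of compound 1 gave a 1.2-fold lower number from compound 1 to compound 2 (0.09 log units; within the scatter), but with only a floor on the core of compound 3, these two pairs neither show that the change carries from one core to the other nor show that it fails to carry.

The compounds shown leave open how far the series would go along this line, for instance whether a longer chain in place of the ethoxy, or an amine or a carboxylic acid at the end of such a chain, would give a number that can be read in this assay. They also leave open what the methoxy to ethoxy change does on the core of compound 1, where a pair would test the same change in a second setting.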